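A few compounds are considered here, and "the series" means these few. Any claim that something is new, unique, unknown or untested is made for them only; others in the source may bear on it.

In a functional assay on K562 cells (Homo sapiens) for antiproliferative activity, read by MTT assay, with a stated time of 72 h (a higher number here means a weaker inhibitor, a lower number a stronger inhibitor), compound 1 `COc1ccc(-c2c(C(=O)c3cc(OC)c(OC)c(OC)c3)sc3ccccc23)cc1` gives 1700 nM. Compound 2 `COc1ccc(-c2c(C(=O)c3cc(OC)c(OC)c(OC)c3)sc3ccccc23)cc1C` differs from it by a methyl in place of hydrogen on an aromatic carbon, and that single measured step is an at least 5.8-fold higher number from compound 1 to compound 2 (0.76 log units; beyond the scatter). Compound 2 reaches only a limit of the assay, > 10000 nM, so it has no exact number and stands at the limit of > 10000 nM in this assay, at which 1 of the 2 values shown sits.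

Compound 3 `COc1cc(C(=O)c2sc3ccccc3c2Nc2ccc(Cl)cc2)cc(OC)c1OC` makes a larger change: (4-chlorophenyl)amino in place of 4-methoxy-3-methylphenyl on an aromatic carbon. The (4-chlorophenyl)amino group replaces the whole 4-methoxy-3-methylphenyl group, so the methyl added in an at least 5.8-fold higher number from compound 1 to compound 2 (0.76 log units; beyond the scatter) is gone. Among the measured compounds shown here, no measured step exchanges this whole group, which leaves the guidance thin. The nearest real number is that of compound 1 at 1700 nM, so a return toward that level is expected, though not with confidence. The expected change is an at least 3.3-fold lower number from compound 2 to compound 3 (0.52 log units; beyond the scatter), toward a stronger inhibitor. For compound 3 the estimated value is 3000 nM, with an expected range of 500 nM to 10000 nM.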

Compound 3, half-maximal inhibitory concentration: 1100 nM
Beside the measured number, compound 3's estimate is 2.7-fold (0.44 log units) above it, within the range that was stated.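

In this assay, exchanging the whole group at this position gives a 1.5-fold lower number from compound 1 to compound 3 (0.19 log units; within the scatter), so the 4-methoxyphenyl and (4-chlorophenyl)amino groups cannot be told apart here. The larger change also restores a measurable value, with an at least 9.0-fold lower number from compound 2 to compound 3 (0.95 log units; beyond the scatter), so this position is not closed to every new group, even though adding a methyl to the 4-methoxyphenyl group produced a clear loss. Compound 2 has only a limit rather than an exact number, which means that this step gives only a minimum size: the limit of > 10000 nM in this assay, at which 1 of the 3 values shown sits.

The compounds shown leave open which part of the new group matters, since the nitrogen and the chlorine entered together. A phenylamino group without the chlorine, or a (4-methoxyphenyl)amino group, would separate the two.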